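The source may report more compounds than this note shows. Statements on the series, on what has been measured and on what is new or still open speak of the compounds shown alone.

Three compounds have so far been measured in a physicochemical assay for solubility, in phosphate buffer, at pH 6.8; on this read-out higher numbers stand for higher solubility and lower numbers for lower solubility:

Compound 1 `CCn1c(NC2CCOCC2)nc2ccsc2c1=O` gives 37 ug/mL.
Compound 2 `CCn1c(NC2CCC2)nc2ccsc2c1=O` gives 6.3 ug/mL.
Compound 3 `CCn1c(N[C@H]2CC[C@H](C(=O)O)CC2)nc2ccsc2c1=O` gives 450 ug/mL.

All three share the same core and differ only in the group carried on a nitrogen on an aromatic ring. On these numbers compound 2 stands lowest: compound 1 lies nearest to it, and compound 3 lies furthest, with a much higher number. Going by the values given here, the one step measured between neighbours is a 5.9-fold lower number from compound 1 to compound 2 (0.77 log units; beyond the scatter), a modest drop that came with the loss of the ring that contains an oxygen.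

Compound 4 `CCn1c(NC(C)(C)C)nc2ccsc2c1=O` has not yet been measured. It is reached from compound 2 by the change (tert-butyl in place of cyclobutyl on a nitrogen on an aromatic ring). This change keeps the same count of carbon atoms and brings in no donor or acceptor; the only thing that goes is the four-membered ring itself. Among the compounds with values here, none of the measured steps covers such a swap of a carbon ring for a branched chain of equal size, so there is no direct precedent to lean on. The step from compound 1 to compound 2 shows that changes at this nitrogen can move the number, but that step also removed an oxygen, which is not the case here.

The expectation is therefore a step of a 1.1-fold higher number from compound 2 to compound 4 (0.05 log units; within the scatter), that is, nothing beyond the scatter in either direction. Compound 4 is estimated at 7 ug/mL, with a likely range from 2.5 ug/mL to 20 ug/mL.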

Compound 4, solubility: 3.7 ug/mL
For compound 4 the middle estimate is 1.9-fold (0.28 log units) above the measured one, and the stated range covers the measured number.
By their numbers in this assay, from the lowest: compounds 4 and 2 (each within the scatter of the next); then compound 1; then compound 3.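

Swapping cyclobutyl for tert-butyl at this nitrogen (a 1.7-fold lower number from compound 2 to compound 4 (0.23 log units; within the scatter)) removes the four-membered ring while keeping the same count of carbon atoms, and the two compounds cannot be told apart in this assay, so here the ring itself makes no readable difference. Going by these compounds alone, compound 1 and compound 4 also differ in one place, and tert-butyl in place of oxan-4-yl (a 10-fold lower number from compound 1 to compound 4 (1.00 log units; beyond the scatter)) puts a second all-carbon group clearly apart from oxan-4-yl, the one group of these three with an oxygen in it. Nothing independent of these solubility numbers is available to explain them.

Still open, as far as these compounds go, is whether an oxygen needs to sit in a ring at all, since a chain such as 2-methoxyethyl on this nitrogen could read closer to compound 1 or closer to compound 2. Also open, from the compounds shown here alone, is how a basic group such as a piperidin-4-yl amine would compare with oxan-4-yl and with the carboxylic acid of compound 3, and whether a smaller all-carbon group such as cyclopropyl would stay with compound 2 and compound 4.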